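Predicting a carbamate on the geranyl-bearing pyridinone core

A few compounds are considered here, and "the series" means these few. Any claim that something is new, unique, unknown or untested is made for them only; others in the source may bear on it.

Measured compounds:
compound 1, `CC(C)=CCC1Cc2c(O)cc(=O)n(CCCO)c2CC1(C)C`, 25.6% in a functional assay on PANC-1 cells (Homo sapiens) for inhibition, read by MTT assay, with a stated time of 24 h, tested at 10 uM; a higher number here means more inhibition at the concentration tested (going by the name of the read-out), a lower number less inhibition
compound 2, `CC(C)=CCC/C(C)=C/CC1Cc2c(O)cc(=O)n(CCCO)c2CC1(C)C`, 28.7% in this assay
compound 3, `CC(C)=CCC1Cc2c(OC(=O)Nc3cccc(C(F)(F)F)c3)cc(=O)n(CCCO)c2CC1(C)C`, 54.3% in this assay

Compound 2 gives the second highest of the three numbers in this assay; its nearest neighbour is compound 1, and the difference a number 3.1 percentage points higher from compound 1 to compound 2 (within the scatter) lies within the scatter, while compound 3 sits well above both. Compound 4, `CC(C)=CCC/C(C)=C/CC1Cc2c(OC(=O)Nc3ccc(Cl)cc3)cc(=O)n(CCCO)c2CC1(C)C`, has not yet been measured. It differs from compound 2 by (4-chlorophenyl)carbamoyl in place of hydrogen on an oxygen on an aromatic ring. Among the compounds with values here, no measured step alters this oxygen on the same core, so the only guide is the pair of compound 1 and compound 3: compound 3 also carries a carbamate on an oxygen on an aromatic ring, and its value in this assay stands clearly above that of compound 1. A similar upward move is therefore expected here, giving an estimated step of a number 23.3 percentage points higher from compound 2 to compound 4 (beyond the scatter). Compound 4 is expected to reach about 52%, within a range from 38% to 66%.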

Compound 4, a percentage reported as inhibition, at one concentration (the size of the read-out at that concentration, not a potency): 47.2%
Estimate against measurement, compound 4: 4.8 percentage points above; measured number inside the range.
By their numbers in this assay, from the lowest: compounds 1 and 2 (each within the scatter of the next); then compounds 4 and 3 (each within the scatter of the next).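

In this assay, within the data shown here, changing hydroxy to ((4-chlorophenyl)carbamoyl)oxy gives a number 18.5 percentage points higher from compound 2 to compound 4 (beyond the scatter), the first measured change at this oxygen on the core with the longer chain. Among these compounds, the only earlier step, the chain extension, stayed within the scatter, so the oxygen on the aromatic ring is the first place in these pairs where a single change clearly moves the number, and carbamates on both chains now stand above their hydroxy parents. Nothing measured here explains the rise.

The chlorine-bearing and trifluoromethyl-bearing carbamates sit on different chains, so the two aromatic groups cannot be ranked against each other. Going by these compounds, what a methyl ether, an acetate ester or a carbamate carrying a cyclohexyl group in place of the aromatic ring would give at this oxygen remains open.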